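This account rests on a few compounds, and the source may have more. Where it says the series, first, only, none or still open, it means among the compounds named here.

Three compounds measured in a functional assay on HCT-116 cells (Homo sapiens) for antiproliferative activity, read by MTT assay, with a stated time of 72 h; on this read-out lower numbers stand for stronger inhibition of growth and higher numbers for weaker inhibition of growth:
Compound 1 `COc1cc(OC)c(/C=C/S(=O)(=O)Cc2cnc(Cl)cn2)c(OC)c1`: > 10000 nM, a limit.
Compound 2 `COc1cc(OC)c(/C=C/S(=O)(=O)Nc2ccc(OC)nc2)c(OC)c1`: 1000 nM.
Compound 3 `COc1cc(OC)c(/C=C/S(=O)(=O)Nc2ccc(Cl)cc2)c(OC)c1`: > 10000 nM, a limit.

Compound 3 has no exact number and sits at the limit of > 10000 nM in this assay, at which 2 of the 3 values shown sit. Compound 4 `CCOc1ccc(NS(=O)(=O)/C=C/c2c(OC)cc(OC)cc2OC)cc1` differs from it in one place, 4-chlorophenyl becoming 4-ethoxyphenyl: ethoxy in place of chloro on an aromatic carbon. Of the two measured steps, a step that the two limits leave unreadable from compound 1 to compound 3 gives no guidance. Within the data shown here, the other, an at least 10-fold higher number from compound 2 to compound 3 (1.00 log units; beyond the scatter), replaces 6-methoxypyridin-3-yl with 4-chlorophenyl, so it is the only readable guide. Since compound 4 swaps chloro for an ethoxy, which resembles the methoxy of compound 2, a partial recovery is expected, toward lower numbers in this assay. The expected change is an at least 4.0-fold lower number from compound 3 to compound 4 (0.60 log units; beyond the scatter). Compound 4 is estimated at 2500 nM, within an expected range of 400 nM to 10000 nM.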

Compound 4, concentration for 50% growth inhibition: 350 nM
Compound 4: the middle estimate sits 7.1-fold (0.85 log units) above what was measured; the measured number lies below the stated range.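

In this assay, ethoxy in place of chloro on this aromatic carbon, para to a large group, gives a large change, an at least 28-fold lower number from compound 3 to compound 4 (1.45 log units; beyond the scatter). Compound 3 stands at a limit, not a number: the limit of > 10000 nM in this assay, at which 2 of the 4 values shown sit. The 4-ethoxyphenyl group on the sulfonamide nitrogen also surpasses 6-methoxypyridin-3-yl, a 2.9-fold lower number from compound 2 to compound 4 (0.46 log units; beyond the scatter), so a ring of carbon only can carry the lower number here.

The compounds shown leave open whether the change follows the oxygen or the ethyl chain. On these data alone, what a methoxy, a longer propoxy chain or an amine would do on this carbon also stays open.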